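Replacing 4-bromophenyl with pyridin-3-yl

The compounds below may be only part of what the source reports. "The series", "measured", "known", "first", "only" and "open" are said of these compounds alone.

In a functional assay on MDA-MB-231 cells (Homo sapiens) for inhibition, read by MTT assay, with a stated time of 48 h (on this read-out higher numbers stand for weaker inhibition of growth and lower numbers for stronger inhibition of growth), compound 1 `S=C(Nc1ccc(Cl)cc1)Nc1ccc2ncnc(Nc3cccc(Br)c3)c2c1` gives 8200 nM. Compound 2 `S=C(Nc1ccc(Br)cc1)Nc1ccc2ncnc(Nc3cccc(Br)c3)c2c1` reads > 30000 nM, which is a limit of the assay and not a number. Compound 3 `S=C(Nc1cccnc1)Nc1ccc2ncnc(Nc3cccc(Br)c3)c2c1` carries pyridin-3-yl in place of 4-bromophenyl on an amide-type nitrogen. Among the measured compounds shown here, the one measured step, an at least 3.6-fold higher number from compound 1 to compound 2 (0.56 log units; beyond the scatter), was only bromo in place of chloro on that group, so it bears on this change indirectly, but it shows that the number can move here. Going by that step, a move toward a lower number is expected, namely an at least 2.1-fold lower number from compound 2 to compound 3 (0.33 log units; beyond the scatter). The estimate for compound 3 is 14000 nM, with an expected range from 5000 nM to 40000 nM.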

Compound 3, concentration for 50% growth inhibition: > 30000 nM
Compound 3: a limit, no number (the forecaster's own chance of this, stated with the estimate: 30%); at least 2.1-fold (0.33 log units) between middle value and limit.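

In this assay compound 3 also gives a limit and not a number, so pyridin-3-yl on this amide-type nitrogen does not bring back a readable value. Set against 4-chlorophenyl, the change gives an at least 3.6-fold higher number from compound 1 to compound 3 (0.56 log units; beyond the scatter), which leaves compound 1 as the only one of the three with a number. The step between compound 2 and compound 3 cannot be read, because both stop at the same limit: the limit of > 30000 nM in this assay, at which 2 of the 3 values shown sit. Still open, as far as these compounds go, is how far past that limit these two compounds lie. Also open, from the compounds shown here alone, is whether unsubstituted phenyl or 4-fluorophenyl on this nitrogen would give a number.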